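Carbamate chain length on the cyclopropyl side chain

The source may hold more compounds than are shown below. What is called first, only, known or untested is meant among the compounds shown, and "the series" means these compounds.

Measured so far in an assay on frontal cortex for displacement of a labelled ligand from corticotropin-releasing factor receptor 1 (Rattus norvegicus), with a stated time of 2 h; on this read-out lower numbers stand for stronger inhibition and higher numbers for weaker inhibition:
compound 1 `COc1nc(C)c(Nc2nc(Cl)cn([C@H](CO)C3CC3)c2=O)cc1C` gives 88 nM
compound 2 `COc1nc(C)c(Nc2nc(Cl)cn([C@H](COC(=O)Nc3cccnc3)C3CC3)c2=O)cc1C` gives 10 nM
compound 3 `CCCNC(=O)OC[C@H](C1CC1)n1cc(Cl)nc(Nc2cc(C)c(OC)nc2C)c1=O` gives 10 nM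

Compound 3 stands level with compound 2 at the digits shown, the two lowest numbers in this assay; compound 1 lies furthest from it, by an 8.8-fold lower number from compound 1 to compound 3 (0.94 log units; beyond the scatter). Compound 4 `CCCCNC(=O)OC[C@H](C1CC1)n1cc(Cl)nc(Nc2cc(C)c(OC)nc2C)c1=O` differs from compound 3 by methyl in place of hydrogen on a saturated chain carbon, three bonds along the chain from an amide-type nitrogen. The step that bears on it is no change at the digits printed from compound 2 to compound 3 (within the scatter), where a much larger exchange on the same amide-type nitrogen left the number within the scatter; the gain from the carbamate itself, an 8.8-fold lower number from compound 1 to compound 3 (0.94 log units; beyond the scatter) and an 8.8-fold lower number from compound 1 to compound 2 (0.94 log units; beyond the scatter), is already present in compound 3. A one-carbon extension is therefore expected to give no step beyond the scatter, no change at the digits printed from compound 3 to compound 4 (within the scatter). For compound 4 the estimate is 10 nM, with a range of 5 nM to 20 nM.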

Compound 4, half-maximal inhibitory concentration: 4.7 nM
Beside the measured number, compound 4's estimate is 2.1-fold (0.33 log units) above it; the whole stated range lies above it.
By their numbers in this assay, from the lowest: compound 4; then compounds 2 and 3 (each within the scatter of the next); then compound 1.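

In this assay the chain on the amide-type nitrogen still responds at propyl: butyl in place of propyl gives a 2.1-fold lower number from compound 3 to compound 4 (0.33 log units; beyond the scatter) as a modest step, which the equal numbers for propyl and pyridin-3-yl did not show. Butyl in place of pyridin-3-yl gives a 2.1-fold lower number from compound 2 to compound 4 (0.33 log units; beyond the scatter) on that nitrogen, and the full butylcarbamoyl gain reaches a 19-fold lower number from compound 1 to compound 4 (1.27 log units; beyond the scatter) as a large step. No measurement shown here explains the effect of the added carbon.

As far as these compounds go, whether a pentyl or longer chain lowers the number further remains open. So does the outcome with a branched chain such as isobutyl, or with a terminal amine or carboxylic acid on the chain.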